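The compounds below may be only part of what the source reports. "The series", "measured", "known", "first", "only" and "open" are said of these compounds alone.

Measured so far in an ADME assay on HEK293 cells (Homo sapiens) for cytotoxicity, read by CellTiter-Glo, with a stated time of 72 h (a higher number here means that more compound is needed for the effect, a lower number that less compound is needed), for the series:
compound 1 `C/C1=C/[C@]23O[C@H]2[C@H](C)C=C3C(=O)[C@@](C)(O)C(=O)CC(C)(C)/C=C/C1=O` gives 26000 nM
compound 2 `CC1=C2CC(C)(C)/C=C/C(=O)/C(C)=C\C3=C[C@H](C)C[C@]3(O2)[C@@]1(O)C#N` gives 26000 nM
compound 3 `C/C1=C/C2=C[C@H](C)C[C@@]23O[C@]2(CC(C)(C)[C@@H](O)[C@@H]2C1=O)[C@@H](C)C3=O` gives 26000 nM

Compound 3 at 26000 nM stands level with compounds 1 and 2, and the three cannot be separated on these numbers.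

Compound 4 `CO[C@H]1[C@@H]2C(=O)/C(C)=C\C3=C[C@H](C)C[C@@]34O[C@]2(CC1(C)C)[C@@H](C)C4=O` departs from compound 3 by one change: methyl in place of hydrogen on an oxygen on a saturated carbon (methyl in place of hydrogen on an oxygen on a saturated carbon, that is, hydroxy to methoxy). Among the measured compounds shown here, no pair of measured compounds differs in one place, so the series holds no direct precedent for this change.

In this assay no step beyond the scatter is expected, and no direction is favoured. This expectation rests on compound 3, which gives 26000 nM here, and on compounds 1 and 2 showing the same figure although their structures differ from it in more than one place. The estimate is no change at the digits printed from compound 3 to compound 4 (within the scatter) as an expected step that stays inside the scatter. For compound 4 the expected value is 26000 nM with an estimated range from 13000 nM to 40000 nM in this read-out.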

Compound 4, half-maximal effective concentration: 26000 nM
Estimate against measurement, compound 4: no gap at the digits printed; measured number inside the range.
By their numbers in this assay, from the lowest: compounds 1, 2, 3 and 4 (each within the scatter of the next).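

In this assay, among the compounds shown here, the change from hydroxy to methoxy gives no change at the digits printed from compound 3 to compound 4 (within the scatter) and is the first step between compounds that differ in one place. It shows that methyl can take the place of hydrogen on this oxygen on a saturated carbon without a readable shift in this read-out, something compounds 1, 2 and 3 could not show, as their structures differ in more than one place. No measurement shown offers an explanation for this result.

Open, from the compounds shown here alone, is whether a longer chain on the same oxygen, such as ethyl or benzyl, would read the same way. Also open, going by these compounds, is how an amine or a carboxylic acid at this saturated carbon, in place of the oxygen group, would read in this assay.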